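A Chloro for Methyl on the Distal Aryl Ring

This account rests on a few compounds, and the source may have more. Where it says the series, first, only, none or still open, it means among the compounds named here.

Three acids sharing one core have been measured in a functional assay on CHO cells for agonist activity at Free fatty acid receptor 1 (Homo sapiens), read by FLIPR and calcium flux, in the presence of a further agent that is not named here; on this read-out lower numbers stand for an effect already at smaller amounts and higher numbers for an effect only at larger amounts of compound. Compound 1 `O=C(O)CCc1ccc(OCc2nc(-c3ccccc3)no2)cc1` gives 1130 nM. Compound 2 `Cc1cc(-c2noc(COc3ccc(CCC(=O)O)cc3)n2)ccc1F` gives 2120 nM. Compound 3 `Cc1ccc(-c2noc(COc3ccc(CCC(=O)O)cc3)n2)cc1` gives 300 nM, the lowest of the three numbers, and its steps from the other two lie beyond the scatter: a 3.8-fold lower number from compound 1 to compound 3 (0.58 log units; beyond the scatter) and a 7.1-fold lower number from compound 2 to compound 3 (0.85 log units; beyond the scatter), whereas a 1.9-fold higher number from compound 1 to compound 2 (0.27 log units; within the scatter) stays within the scatter. Compound 4 `O=C(O)CCc1ccc(OCc2nc(-c3ccc(Cl)cc3)no2)cc1` has not yet been measured; it differs from compound 3 by chloro in place of methyl on an aromatic carbon. Going by the values given here, no measured step exchanges chloro for methyl, so the two steps ending at compound 3 bear only indirectly on it: a methyl placed on the bare phenyl of compound 1 lowered the number, while the fluorinated and methylated phenyl of compound 2 gave a higher one. Since one heavy atom replaces another on the same aromatic carbon, compound 4 is expected to show a 1.5-fold higher number from compound 3 to compound 4 (0.18 log units; within the scatter), a step that may not exceed the scatter. The estimate for compound 4 in this assay is 450 nM, within 150 nM to 1400 nM.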

Compound 4, half-maximal effective concentration in the Free fatty acid receptor 1 assay: 540 nM
Compound 4: middle estimate off by 1.2-fold (0.08 log units), on the low side, and the stated range covers the measured number.
By their numbers in the Free fatty acid receptor 1 assay, from the lowest: compounds 3 and 4 (each within the scatter of the next); then compounds 1 and 2 (each within the scatter of the next).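

In the Free fatty acid receptor 1 assay compound 3 gives 300 nM and compound 4 gives 540 nM. In the Free fatty acid receptor 1 assay chloro in place of methyl on this aromatic carbon, para to a large group, is a step that stays within the scatter (a 1.8-fold higher number from compound 3 to compound 4 (0.26 log units; within the scatter)). Chloro in place of hydrogen also stands beyond the scatter (a 2.1-fold lower number from compound 1 to compound 4 (0.32 log units; beyond the scatter)), as does 4-chlorophenyl in place of 4-fluoro-3-methylphenyl (a 3.9-fold lower number from compound 2 to compound 4 (0.59 log units; beyond the scatter)), so methyl is no longer the only group shown on this carbon to give a lower number than the bare phenyl. In a physicochemical assay for solubility, in phosphate buffer, measured as kinetic solubility, at pH 7.4 (a higher number here means a more soluble compound, a lower number a less soluble compound), compound 3 gives 334000 nM and compound 4 gives 214000 nM. In the physicochemical assay the same pair likewise stays within the scatter (a 1.6-fold lower number from compound 3 to compound 4 (0.19 log units; within the scatter)).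

Nothing at hand offers an explanation for these steps. On these data alone, whether a methoxy group, a nitrile or a trifluoromethyl group on the same carbon would fall with chloro and methyl remains open.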